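Carboxy to methylcarbamoyl: a small step, slow clearance expected

A few compounds are considered here, and "the series" means these few. Any claim that something is new, unique, unknown or untested is made for them only; others in the source may bear on it.

Compound 2 `O=C(O)c1ccc(C(=O)C2=C(O)C(=O)N(c3ccc(-c4ccon4)cc3)C2C2CCCCC2)cc1` shows the lowest number of the two measured in an ADME assay on the whole organism (Rattus norvegicus) for pharmacokinetics (on this read-out lower numbers stand for slow clearance and higher numbers for fast clearance), with 1.9 mL/min/kg; its nearest neighbour, compound 1 `O=C(C1=C(O)C(=O)N(c2ccc(-c3ccon3)cc2)C1C1CCCCC1)c1ccc(CO)cc1`, gives 3.8 mL/min/kg in this assay. For the measured compounds named here, the only step available, a 2.0-fold lower number from compound 1 to compound 2 (0.30 log units; within the scatter), changed the same aromatic carbon substituent and stayed within the scatter. Compound 3 `CNC(=O)c1ccc(C(=O)C2=C(O)C(=O)N(c3ccc(-c4ccon4)cc3)C2C2CCCCC2)cc1` is not yet measured; it differs from compound 2 by methylamino in place of hydroxy on a carbonyl carbon. Going by the values given here, that earlier step is the only guide, and it bears on the same part of the molecule, so a step of similar size, either direction, or none beyond the scatter is what is expected for compound 3 in this assay, with a 1.6-fold higher number from compound 2 to compound 3 (0.20 log units; within the scatter) as the estimated step. The value expected for compound 3 in this assay is therefore 3 mL/min/kg, with a range from 1.2 mL/min/kg to 8 mL/min/kg.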

Compound 3, clearance: 17.6 mL/min/kg
For compound 3 the middle estimate is 5.9-fold (0.77 log units) below the measured one; measured number above the stated range.
By their numbers in this assay, from the lowest: compounds 2 and 1 (each within the scatter of the next); then compound 3.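

At this position the group matters more than the step from hydroxymethyl to carboxy suggested, since that step stayed within the scatter in this assay. Methylamino in place of hydroxy on the carbonyl carbon gives a 9.3-fold higher number from compound 2 to compound 3 (0.97 log units; beyond the scatter), and methylcarbamoyl in place of hydroxymethyl on the aromatic carbon gives a 4.6-fold higher number from compound 1 to compound 3 (0.67 log units; beyond the scatter), so the methylcarbamoyl group stands apart from both other groups. Nothing available explains why this change has so large an effect on clearance.

What remains open is whether the rise goes with the amide as such or with its methyl, as neither carbamoyl nor dimethylcarbamoyl is among the compounds shown. Where a methyl ester on the same carbonyl carbon would fall in this assay is also unknown.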